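The compounds below may be only part of what the source reports. "The series", "measured", "known", "first", "only" and "open" are said of these compounds alone.

compound 1 (`c1ccc(C(c2c[nH]c3ccccc23)c2c[nH]c3ccccc23)cc1`) gives 40000 nM
compound 2 (`COc1ccc(C(c2c[nH]c3ccc(Br)cc23)c2c[nH]c3ccc(Br)cc23)cc1OC`) gives 12000 nM
compound 3 (`CN(C)c1ccc(C(c2c[nH]c3ccc(Br)cc23)c2c[nH]c3ccc(Br)cc23)cc1`) gives 25000 nM

In a functional assay on A549 cells (Homo sapiens) for inhibition, read by MTT assay, with a stated time of 48 h (a higher number here means a weaker inhibitor, a lower number a stronger inhibitor), compound 2 stands lowest of the three at 12000 nM and is the strongest inhibitor measured so far. The next compound is compound 4 (`O=[N+]([O-])c1ccc(C(c2c[nH]c3ccc(Br)cc23)c2c[nH]c3ccc(Br)cc23)cc1`), in which 4-nitrophenyl takes the place of 3,4-dimethoxyphenyl on a saturated chain carbon bound to two aromatic carbons (4-nitrophenyl in place of 3,4-dimethoxyphenyl on a saturated chain carbon bound to two aromatic carbons). Going by the values given here, only one measured step replaces that same group at that same place, with 4-(dimethylamino)phenyl entering (a 2.1-fold higher number from compound 2 to compound 3 (0.32 log units; beyond the scatter)). Among the compounds with values here, that step is modest, and no measured compound carries a 4-nitrophenyl group, so this single step is the only guide and the direction remains uncertain. A step of similar modest size towards a higher number is therefore expected in this assay. The estimated change is a 1.7-fold higher number from compound 2 to compound 4 (0.22 log units; within the scatter) as a central figure. For compound 4 the expected value is 20000 nM with an estimated range from 7000 nM to 50000 nM in this assay.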

Compound 4, half-maximal inhibitory concentration: 5500 nM
For compound 4 the middle estimate is 3.6-fold (0.56 log units) above the measured one, and the stated range ends above it.
By their numbers in this assay, from the lowest: compound 4; then compound 2; then compounds 3 and 1 (each within the scatter of the next).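

In this assay, changing the group on a saturated chain carbon bound to two aromatic carbons can lower the number as well as raise it: 4-nitrophenyl in place of 3,4-dimethoxyphenyl gives a step the other way from the earlier 4-(dimethylamino)phenyl change (a 2.2-fold lower number from compound 2 to compound 4 (0.34 log units; beyond the scatter)). The pair that differs only by nitro in place of dimethylamino on an aromatic carbon shows a wider spread (a 4.5-fold lower number from compound 3 to compound 4 (0.66 log units; beyond the scatter)), so the choice of this single group matters within the series. No measurement at hand accounts for either step.

As far as these compounds go, it remains open how a 4-aminophenyl or 4-carboxyphenyl group would behave at this place. Going by these compounds alone, compound 1 differs from the others in more than one place, so no pair here isolates the effect of the bromine atoms on the shared core.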